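Trimming the Benzoxazole to a Dimethylamino Group

The compounds below may be only part of what the source reports. "The series", "measured", "known", "first", "only" and "open" are said of these compounds alone.

Compound 1 `c1ccc(-c2ccc(Cn3cncc3CNc3ccc(-c4nc5ccccc5o4)c(-c4ccccc4)c3)cc2)cc1` was tested in a toxicity assay on NIH3T3 cells (Mus musculus) for cytotoxicity, read by resazurin assay (a higher number here means that more compound is needed for the effect, a lower number that less compound is needed), where compound 1 gives > 10000 nM, a limit of the assay rather than a number. Compound 2 `CS(=O)(=O)c1ccc(Cn2cncc2CNc2ccc(-c3nc4ccccc4s3)c(-c3ccccc3)c2)cc1` gives > 1000 nM in this assay, also a limit. Among the compounds with values here, compound 1 thus stands at the limit of > 10000 nM in this assay, at which 1 of the 2 values shown sits, while the only other value sits at the limit of > 1000 nM in this assay, at which 1 of the 2 values shown sits. Compound 3 `CN(C)c1ccc(NCc2cncn2Cc2ccc(-c3ccccc3)cc2)cc1-c1ccccc1` differs from compound 1 by dimethylamino in place of 1,3-benzoxazol-2-yl on an aromatic carbon. Within the data shown here, no measured step guides this change, so the step of a number no higher from compound 1 to compound 3 (the limit leaves the size open) is expected to stay within the scatter, with no real direction. Compound 3 is estimated at 10000 nM, in a range from 3000 nM to 30000 nM.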

Compound 3, half-maximal effective concentration: > 1000 nM
Compound 3: a limit, no number; the forecaster's own chance of this, stated with the estimate: 70%; the middle value lies beyond the limit too.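

Compound 3 gives > 1000 nM in this assay, a limit and not a number. Compound 1 also stands at a limit, and the step between compound 1 and compound 3 cannot be read. The compounds shown leave open whether dimethylamino in place of 1,3-benzoxazol-2-yl changes cytotoxicity at all.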